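This account rests on a few compounds, and the source may have more. Where it says the series, first, only, none or still open, it means among the compounds named here.

Values in an ADME assay on the whole organism (strain CD-1) for metabolic stability, with Mus musculus as the target, at a dose of 50 mg/kg by the oral route (on this read-out lower numbers stand for a shorter-lived compound and higher numbers for a longer-lived compound), for the measured compounds:
- compound 1 `O=C(NC[C@@H]1CC(Br)=NO1)[C@@H]1C[C@@H](c2ccc(O)cc2)CN1C(=O)OCc1cnc2ccccc2c1` gives 0.25 h
- compound 2 `O=C(N[C@@H]1C[C@@H](C(=O)NC[C@@H]2CC(Br)=NO2)N(C(=O)OCc2cnc3ccccc3c2)C1)c1ccc(O)cc1` gives 0.25 h
- compound 3 `O=C(NC[C@@H]1CC(Br)=NO1)[C@@H]1CCCN1C(=O)OCc1cnc2ccccc2c1` gives 0.25 h

Level with compounds 1 and 2, compound 3 sits at 0.25 h with no separation from either. The next structure, compound 4 `O=C(NC[C@@H]1CC(Br)=NO1)[C@@H]1C[C@@H](OCc2ccccc2)CN1C(=O)OCc1cnc2ccccc2c1`, has benzyloxy in place of hydrogen on a saturated ring carbon of the five-membered non-aromatic ring, two ring bonds from the ring nitrogen. The counted difference reads benzyloxy in place of hydrogen on a saturated ring carbon and adds a large group where compound 3 has none.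

Within the data shown here, three measured steps bear on this. Taking away 4-hydroxyphenyl gave no change at the digits printed from compound 1 to compound 3 (within the scatter) and taking away ((4-hydroxyphenyl)carbonyl)amino gave no change at the digits printed from compound 2 to compound 3 (within the scatter). Exchanging one of these groups for the other gave no change at the digits printed from compound 1 to compound 2 (within the scatter). Among the measured compounds shown here, none of the three shows any size at all, though they run in the opposite direction or sideways, and no measured compound carries benzyloxy. On that limited evidence, no shift beyond the scatter is expected in this assay, in either direction.

The expected step is no change at the digits printed from compound 3 to compound 4 (within the scatter) and should stay within the scatter. The estimate for compound 4 is 0.25 h, with an expected range from 0.15 h to 0.5 h.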

Compound 4, half-life: 0.25 h
For compound 4 middle estimate and measured number coincide at the digits printed, and the stated range covers the measured number.
By their numbers in this assay, from the lowest: compounds 1, 2, 3 and 4 (each within the scatter of the next).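

In this assay, benzyloxy brings a large group onto the saturated ring carbon two ring bonds from the ring nitrogen, where compound 3 has only hydrogen, and the result is no change at the digits printed from compound 3 to compound 4 (within the scatter). Set against the two other large groups at this carbon, benzyloxy in place of ((4-hydroxyphenyl)carbonyl)amino gives no change at the digits printed from compound 2 to compound 4 (within the scatter), and benzyloxy in place of 4-hydroxyphenyl gives no change at the digits printed from compound 1 to compound 4 (within the scatter), so this position now reads flat across hydrogen and three large groups, including one with 0 hydrogen-bond donors as counted. No supporting data on hand accounts for this flat read-out.

On these data alone, whether a primary amine, a carboxylic acid or a longer chain on this carbon would separate from the four compounds on this half-life read-out remains open. Also open is what a change elsewhere in the shared core would do, since every step shown here lies at this one carbon.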